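Benzothiazolyl semicarbazones: dimethylamino to diethylamino on two cores

The compounds below may be only part of what the source reports. "The series", "measured", "known", "first", "only" and "open" are said of these compounds alone.

Compound 1 `CN(C)Cc1ccc2nc(NC(=O)N/N=C3\C(=O)Nc4ccc(F)cc43)sc2c1` and compound 2 `CCN(CC)Cc1ccc2nc(NC(=O)N/N=C3\C(=O)Nc4ccc(F)cc43)sc2c1` share one core and differ by diethylamino in place of dimethylamino on a saturated chain carbon bound to an aromatic carbon. In a functional assay on NCI-H460 cells (Homo sapiens) for cytotoxicity, read by MTT assay, with a stated time of 72 h (a lower number here means a stronger inhibitor, a higher number a weaker inhibitor), compound 1 gives 1550 nM, and compound 2 gives 1060 nM; the step is a 1.5-fold lower number from compound 1 to compound 2 (0.17 log units; within the scatter).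

Compound 3 `CN(C)Cc1ccc2nc(NC(=O)N/N=C/c3cn(Cc4ccc(Cl)c(Cl)c4)c4ccccc34)sc2c1` carries the dimethylamino group of compound 1 on a different core; the difference between the two cores is not broken down here. In this assay compound 3 gives 1360 nM, which lies within the scatter of compound 1 and of compound 2.

Compound 4 `CCN(CC)Cc1ccc2nc(NC(=O)N/N=C/c3cn(Cc4ccc(Cl)c(Cl)c4)c4ccccc34)sc2c1` is not yet measured. It differs from compound 3 by diethylamino in place of dimethylamino on a saturated chain carbon bound to an aromatic carbon, the same change seen from compound 1 to compound 2, at the same place on a saturated chain carbon bound to an aromatic carbon.

Among the measured compounds shown here, the only guide is the single measured step of a 1.5-fold lower number from compound 1 to compound 2 (0.17 log units; within the scatter), which stayed within the scatter. Expected on that basis is a 1.4-fold lower number from compound 3 to compound 4 (0.13 log units; within the scatter), a small step that could as well be flat. Compound 4 is therefore expected to give about 1000 nM in this assay, with a range from 500 nM to 2000 nM.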

Compound 4, half-maximal inhibitory concentration: 610 nM
For compound 4 the middle estimate is 1.6-fold (0.21 log units) above the measured one; low and high end bracket the measured number.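

In this assay, diethylamino in place of dimethylamino on the core of compound 3 gives a 2.2-fold lower number from compound 3 to compound 4 (0.35 log units; beyond the scatter), a modest step. Set beside the step on the core of compound 1, it runs the same way and cannot be told apart from it: the same change on two cores in this assay, a 1.5-fold lower number (0.17 log units; within the scatter) from compound 1 to compound 2 and a 2.2-fold lower number (0.35 log units; beyond the scatter) from compound 3 to compound 4, 1.5-fold (0.18 log units) apart, within the scatter of two such steps. This shows that the change carries over to a second core with a step of similar size, but two cores cannot show that it holds throughout the series, that the size of the step depends on the core, or why the step arises.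

Open, on these data alone, is how other amines, such as dipropylamino or a primary amine, would read on a saturated chain carbon bound to an aromatic carbon on either core. Also open, as far as these compounds go, is whether a longer chain carrying the diethylamino group would extend the same small trend in this cell assay or leave the numbers flat on these two cores.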